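This account rests on a few compounds, and the source may have more. Where it says the series, first, only, none or still open, it means among the compounds named here.

Compound 1 `O=C(/C=C/c1coc2cc(O)ccc2c1=O)NCc1ccc(F)cc1` is the starting point, and it is followed through a functional assay on L02 cells (Homo sapiens) for inhibition, read by MTT assay, with a stated time of 48 h; a higher number here means a weaker inhibitor, a lower number a stronger inhibitor. In this assay compound 1 gives > 200000 nM, which is a limit of the assay rather than a measured number. Two related compounds stand beside it. Compound 2 `COc1ccc2c(=O)c(/C=C/C(=O)Nc3ccccc3)coc2c1` gives > 200000 nM in this assay, again a limit. Compound 3 `COc1ccc(CNC(=O)/C=C/c2coc3cc(OC)ccc3c2=O)cc1` gives > 200000 nM in this assay, once more a limit. Among the measured compounds shown here, the one step between measured compounds, a step that the two limits leave unreadable from compound 2 to compound 3, therefore cannot be read as a size, because the limit of > 200000 nM in this assay, at which 3 of the 3 values shown sit, is where all three values sit.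

Compound 4 `Cc1ccc(CNC(=O)/C=C/c2coc3cc(O)ccc3c2=O)cc1` has not yet been measured. It differs from compound 1 by methyl in place of fluoro on an aromatic carbon. No measured step involves this change, and the only step shown gives no readable size at all, so there is nothing among the measured compounds that points to a stronger or a weaker inhibitor after this change.

On that basis compound 4 is expected to give 300000 nM in this assay, with an estimated range from 100000 nM to 1000000 nM, and the result is most likely to be reported as a limit once again. The step that the limit leaves unreadable from compound 1 to compound 4 that this estimate implies is expected to be none beyond the scatter.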

Compound 4, half-maximal inhibitory concentration: > 200000 nM
Compound 4 was reported as a limit; the forecaster's own chance of this, stated with the estimate: 85%; the middle value does not contradict the limit.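

Compound 1 and compound 4 both stand at a limit rather than a number, so no size can be read for the change from fluoro to methyl, and no new step emerges: the limit of > 200000 nM in this assay, at which 4 of the 4 values shown sit.

The compounds shown leave open whether any change to the shared core would give a readable number in this assay.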